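The source may hold more compounds than are shown below. What is called first, only, known or untested is meant among the compounds shown, and "the series" means these compounds.

Measured so far in a functional assay on CCRF-CEM cells (Homo sapiens) for inhibition, read by sulforhodamine B assay, with a stated time of 48 h; on this read-out higher numbers stand for weaker inhibition of growth and lower numbers for stronger inhibition of growth:
compound 1 `COc1ccc(-c2[nH]c3ccccc3c2/C=C(\C#N)S(=O)(=O)c2ccccc2)cc1` gives 1300 nM
compound 2 `CC(=O)/C(=C\c1c(-c2ccccc2)[nH]c2ccccc12)S(=O)(=O)c1ccccc1` gives 1400 nM
compound 3 `COc1ccc2[nH]c(-c3ccccc3)c(/C=C(\C#N)S(=O)(=O)c3ccccc3)c2c1` gives 6500 nM

Compound 3 stands highest of the three numbers in this assay; compound 2 and compound 1 both sit well below it, each gap beyond the scatter. Among the measured compounds shown here, no two of the measured compounds differ in one place only, so no single step is quantified. Compound 4 `N#C/C(=C\c1c(-c2ccccc2)[nH]c2ccccc12)S(=O)(=O)c1ccccc1` is the next member: relative to compound 3 the change is hydrogen in place of methoxy on an aromatic carbon. Compound 2, which also carries no substituent on the fused ring, gives 1400 nM; on that basis the step from compound 3 to compound 4 is expected to lower the number, roughly a 4.3-fold lower number from compound 3 to compound 4 (0.64 log units; beyond the scatter). Compound 4 is therefore estimated at 1500 nM, range 500 nM to 5000 nM.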

Compound 4, concentration for 50% growth inhibition: 2600 nM
Estimate against measurement, compound 4: 1.7-fold (0.24 log units) below, within the range that was stated.
By their numbers in this assay, from the lowest: compounds 1, 2 and 4 (each within the scatter of the next); then compound 3.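

In this assay this aromatic carbon, part of a fused or bridged system of two rings, does not tolerate methoxy without cost: hydrogen in its place gives a 2.5-fold lower number from compound 3 to compound 4 (0.40 log units; beyond the scatter). The same exchange at the methoxy place of compound 1 gives a 2.0-fold higher number from compound 1 to compound 4 (0.30 log units; within the scatter), so the outcome depends on place, while cyano in place of acetyl gives a 1.9-fold higher number from compound 2 to compound 4 (0.27 log units; within the scatter). No measurement here accounts for these steps. Open, going by these compounds, is whether a smaller group such as fluorine or hydroxyl at this carbon behaves like methoxy or like hydrogen. Also open, on these data alone, is how an amide would compare with cyano and acetyl on the chain carbon.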